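Difluorophenyl anilino analogue in the cell assay

This account rests on a few compounds, and the source may have more. Where it says the series, first, only, none or still open, it means among the compounds named here.

Compound 2 `CCn1c(=O)/c(=C2\Sc3ccccc3N2C)s/c1=C\c1ccncc1Nc1ccccc1Cl` carries a 2-chlorophenyl on the anilino nitrogen of the shared core. In a functional assay on PC-3 cells (Homo sapiens) for inhibition (a lower number here means a stronger inhibitor, a higher number a weaker inhibitor), compound 2 gives 780 nM, and its methyl counterpart, compound 1 `CCn1c(=O)/c(=C2\Sc3ccccc3N2C)s/c1=C\c1ccncc1Nc1ccccc1C`, gives 1200 nM in this assay; the two stand within the scatter of each other, the step of a 1.5-fold lower number from compound 1 to compound 2 (0.19 log units; within the scatter) being too small to rank them. Compound 3 `CCn1c(=O)/c(=C2\Sc3ccccc3N2C)s/c1=C\c1ccncc1Nc1cc(F)ccc1F` is the next analogue, differing by 2,5-difluorophenyl in place of 2-chlorophenyl on a nitrogen on an aromatic ring. Among the compounds with values here, the one measured step bears on it only loosely, since it too swaps the substituent on that same aromatic ring, and it changed little. A change of similar size is therefore expected for the step of a 1.2-fold higher number from compound 2 to compound 3 (0.09 log units; within the scatter), with no direction claimed beyond the scatter. Compound 3 is accordingly estimated at 950 nM in this assay, within a range from 350 nM to 2600 nM.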

Compound 3, half-maximal inhibitory concentration: 1200 nM
Beside the measured number, compound 3's estimate is 1.3-fold (0.10 log units) below it; low and high end bracket the measured number.
By their numbers in this assay, from the lowest: compounds 2, 1 and 3 (each within the scatter of the next).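

In this assay, 2,5-difluorophenyl in place of 2-chlorophenyl gives a 1.5-fold higher number from compound 2 to compound 3 (0.19 log units; within the scatter), and 2,5-difluorophenyl in place of 2-methylphenyl gives no change at the digits printed from compound 1 to compound 3 (within the scatter). Within the data shown here, the earlier pair compared only two groups. With a third group on the same nitrogen, compounds 1, 2 and 3 all lie within the scatter of each other, so the data give no order among these three aryl groups, including the one with a second ring substituent. No supporting evidence accounts for this close agreement.

On these data alone, it remains open whether any group on this nitrogen can move the number beyond the scatter. A phenyl ring carrying an amine or a carboxylic acid, or a longer alkyl chain in place of the ring, could test this.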